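This account rests on a few compounds, and the source may have more. Where it says the series, first, only, none or still open, it means among the compounds named here.

Compound 3 `CN(C)CCCNc1nc(-c2ccccc2)nc2ccccc12` stands at > 100000 nM in a toxicity assay on cells (Macrophage, Homo sapiens) for inhibition, read by MTT assay (a higher number here means a weaker inhibitor, a lower number a stronger inhibitor), and this is a limit of the assay, not a number. Compound 4 `COc1ccc(-c2nc(NCCCN(C)C)c3ccccc3n2)cc1` carries methoxy in place of hydrogen on an aromatic carbon, para to a large group: methoxy in place of hydrogen on an aromatic carbon. For the measured compounds named here, the only measured step, a 1.2-fold higher number from compound 1 to compound 2 (0.06 log units; within the scatter), lies within the scatter and concerns the chain, not this ring, so it gives no direct size for the change. In this assay compound 1 `NCCCCNc1nc(-c2ccc(Cl)cc2)nc2ccccc12` gives 13000 nM and compound 2 `NCCNc1nc(-c2ccc(Cl)cc2)nc2ccccc12` gives 15000 nM; both carry a substituent on that ring, although their chains also differ from that of compound 3. On those two values, a modest move toward a lower number is expected, estimated as an at least 1.6-fold lower number from compound 3 to compound 4 (0.22 log units; that floor lies within the scatter). For compound 4 the expected value is 60000 nM, with an estimated range from 20000 nM to 120000 nM.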

Compound 4, half-maximal inhibitory concentration: 67500 nM
Beside the measured number, compound 4's estimate is 1.1-fold (0.05 log units) below it; the range from low to high includes it.
By their numbers in this assay, from the lowest: compounds 1 and 2 (each within the scatter of the next); then compound 4. At a limit, above all of these: compound 3.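

In this assay, methoxy in place of hydrogen on an aromatic carbon, para to a large group, gives the first step measured on this ring: an at least 1.4-fold lower number from compound 3 to compound 4 (0.17 log units; that floor lies within the scatter). With the chain of compound 3 kept, compound 4 gives a measurable number, 67500 nM. Compound 3 stands at a limit of the assay, not a number, so this step has only a floor: the limit of > 100000 nM in this assay, at which 1 of the 4 values shown sits.

Going by these compounds, the true size of the step remains open. So does how hydroxy or a carboxylic acid on that aromatic carbon would read against compound 4.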